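The compounds below may be only part of what the source reports. "The series", "measured", "known", "first", "only" and "open" are said of these compounds alone.

Compound 1 `CC(C(=O)O)c1nn(Cc2cn3cc(OCC4CC4)c(Cl)cc3n2)c2ccccc2c1=O`: 6 nM
Compound 2 `O=C(O)Cn1nc(Cc2nc3cc(F)c(OCC4CC4)cc3[nH]2)c2ccccc2c1=O`: 18 nM
Compound 3 `COc1cc(OC)c(NC(=O)Cc2cn(CC(=O)O)c3ccccc23)cc1Cl`: > 6640 nM

In a functional assay on CHO cells for antagonist activity at sphingosine 1-phosphate receptor 2 (Homo sapiens), read by calcium flux (a lower number here means a stronger inhibitor, a higher number a weaker inhibitor), compound 1 holds the lowest of the two numbers; compound 2 sits at a higher number, a gap beyond the usual scatter. For compound 3 the assay reports only a limit, (the limit of > 6640 nM in this assay, at which 1 of the 3 values shown sits). Compound 4 `CC(C)(C(=O)O)c1nn(Cc2cn3cc(OCC4CC4)c(Cl)cc3n2)c2ccccc2c1=O` differs from compound 1 by methyl in place of hydrogen on a saturated chain carbon bound to an aromatic carbon, a carbonyl carbon and a saturated chain carbon, so the 1-carboxyethyl chain becomes 1-carboxy-1-methylethyl. For the measured compounds named here, no measured pair shows this change, so its size can only be estimated; a change of this kind is expected to leave the number within the scatter or move it modestly upward. Compound 4 is therefore expected to sit near 12 nM, between 4 nM and 40 nM. That estimate means a step of a 2.0-fold higher number from compound 1 to compound 4 (0.30 log units; within the scatter), expected to be small.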

Compound 4, half-maximal inhibitory concentration: 7.7 nM
Compound 4: middle estimate off by 1.6-fold (0.19 log units), on the high side, within the range that was stated.
By their numbers in this assay, from the lowest: compounds 1 and 4 (each within the scatter of the next); then compound 2. At a limit, above all of these: compound 3.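

In this assay, the change from 1-carboxyethyl to 1-carboxy-1-methylethyl gives a 1.3-fold higher number from compound 1 to compound 4 (0.11 log units; within the scatter). The saturated chain carbon bearing the carboxylic acid therefore accepts a methyl in place of its hydrogen, and that hydrogen is not needed to keep the number in this range. Nothing measured here gives a cause for this result.

The compounds shown leave open whether an ethyl group or a longer chain on this carbon would be accepted as well. They also leave open whether an amide could stand in place of the carboxylic acid.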